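Two Aminophenyl Isomers and a Cytotoxicity Estimate

This account rests on a few compounds, and the source may have more. Where it says the series, first, only, none or still open, it means among the compounds named here.

Compound 1 `COc1ccc(/C=C\c2ccc3c(c2)C(C)(C)CCC3(C)C)cc1N` gives 48000 nM
Compound 2 `CC1(C)CCC(C)(C)c2cc(/C=C\c3ccc(N)cc3)ccc21` gives 25000 nM

Among the measured compounds shown here, in a functional assay on HL-60 cells (Homo sapiens) for cytotoxicity, with a stated time of 48 h (a lower number here means a stronger inhibitor, a higher number a weaker inhibitor), compound 2 at 25000 nM and compound 1 at 48000 nM lie within the usual scatter of each other, so compound 2 stands level with the only other measured compound. Compound 3 `CC1(C)CCC(C)(C)c2cc(/C=C\c3cccc(N)c3)ccc21` has the same atoms as compound 2, joined differently, and 3-aminophenyl in place of 4-aminophenyl on a double-bonded chain carbon bound to a double-bonded chain carbon describes the change, with 3-aminophenyl in place of 4-aminophenyl on a double-bonded chain carbon bound to a double-bonded chain carbon. For the measured compounds named here, no measured pair shows this change on its own. Going by the values given here, the only guide is that compound 1, at 48000 nM despite its different structure, stays within the scatter of compound 2. No shift beyond the scatter is therefore expected in this assay and the estimated 1.0-fold lower number from compound 2 to compound 3 (0.02 log units; within the scatter) has no clear direction. For compound 3 the estimated value is 24000 nM with an expected range from 9000 nM to 60000 nM in this test.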

Compound 3, half-maximal inhibitory concentration: 15000 nM
Compound 3: middle estimate off by 1.6-fold (0.20 log units), on the high side; the range from low to high includes it.
By their numbers in this assay, from the lowest: compounds 3, 2 and 1 (each within the scatter of the next, the first and the last beyond it).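

In this assay, 3-aminophenyl in place of 4-aminophenyl gives a 1.7-fold lower number from compound 2 to compound 3 (0.22 log units; within the scatter), so at this place on the chain the two isomers cannot be told apart. Among the compounds shown here, compound 3 also brings the first step beyond the scatter: hydrogen in place of methoxy on an aromatic carbon gives a 3.2-fold lower number from compound 1 to compound 3 (0.51 log units; beyond the scatter), a modest step resting on this single pair. Nothing on hand explains either step.

The compounds shown leave open whether the step seen with methoxy would also appear with another group on that aromatic carbon, such as ethoxy or a chlorine atom. They also leave open whether the amine matters at all, a question that a hydroxyl or a carboxylic acid in its place could address.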